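A few compounds are considered here, and "the series" means these few. Any claim that something is new, unique, unknown or untested is made for them only; others in the source may bear on it.

In a functional assay on NCI-H1581 cells (Homo sapiens) for antiproliferative activity, read by CCK-8 assay, with a stated time of 72 h (on this read-out lower numbers stand for stronger inhibition and higher numbers for weaker inhibition), compound 1 `COc1cc(OC)c(Cl)c(-c2ccc3c(NC(=O)c4ccc(N5CCCCC5)cc4)n[nH]c3n2)c1Cl` gives 558 nM, while compound 2 `COc1cc(OC)c(Cl)c(-c2ccc3c(NC(=O)c4ccc(N5CCCN(C)CC5)cc4)n[nH]c3n2)c1Cl` gives 1.3 nM, the lower of the two numbers. Compound 3 `CCN1CCN(c2ccc(C(=O)Nc3n[nH]c4nc(-c5c(Cl)c(OC)cc(OC)c5Cl)ccc34)cc2)CC1` has 4-ethylpiperazin-1-yl in place of 4-methyl-1,4-diazepan-1-yl on an aromatic carbon. Among the measured compounds shown here, the only measured step, a 430-fold lower number from compound 1 to compound 2 (2.63 log units; beyond the scatter), is large, but it involved piperidin-1-yl, which plays no part in this exchange. It shows that this group can matter, without sizing the new change. The two groups here have the same atoms, so only a small rise in this assay is expected, a 2.3-fold higher number from compound 2 to compound 3 (0.36 log units; beyond the scatter). For compound 3 the estimated value is 3 nM, within a range of 0.8 nM to 12 nM.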

Compound 3, half-maximal inhibitory concentration: 0.7 nM
Compound 3: middle estimate off by 4.3-fold (0.63 log units), on the high side; measured number below the stated range.
By their numbers in this assay, from the lowest: compounds 3 and 2 (each within the scatter of the next); then compound 1.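

In this assay the six-membered 4-ethylpiperazin-1-yl in place of the seven-membered 4-methyl-1,4-diazepan-1-yl gives a 1.9-fold lower number from compound 2 to compound 3 (0.27 log units; within the scatter) and so no readable change, which means this position accepts both rings. Against piperidin-1-yl, the new group gives an 800-fold lower number from compound 1 to compound 3 (2.90 log units; beyond the scatter) in the same direction as the earlier step, so two different rings with a second nitrogen now stand apart from compound 1. Nothing measured here explains that gap.

On these data alone, whether the second nitrogen itself matters remains open. A morpholine ring, or a piperazine with a longer chain on that nitrogen, would help to answer this.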